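A few compounds are considered here, and "the series" means these few. Any claim that something is new, unique, unknown or untested is made for them only; others in the source may bear on it.

Measured compounds:
- compound 1 `Cc1ccccc1-n1nc(C)c2c1NC(=O)[C@H](C)S[C@@H]2c1ccc(/C=C/c2ccccc2)cc1`: "not active" (no number reported)
- compound 2 `COC(=O)c1cccc(-c2ccc([C@H]3S[C@@H](C)C(=O)Nc4c3c(C)nn4-c3ccccc3C)cc2)c1`: "not active" (no number reported)
- compound 3 `Cc1ccccc1-n1nc(C)c2c1NC(=O)[C@H](C)S[C@@H]2c1ccc(-c2ccsc2)cc1`: 1400 nM

The account follows the shared core of these compounds into a fourth member. For the measured compounds named here, in an assay on isolated protein for agonist activity at Bile acid receptor (Homo sapiens), read by AlphaScreen, with a stated time of 30 min (on this read-out lower numbers stand for an effect already at smaller amounts and higher numbers for an effect only at larger amounts of compound), compound 3 gives 1400 nM, and this is the only number obtained for the series; compound 1 and compound 2 returned no number in this assay, so compound 3 stands alone as the single quantified point, with nothing to rank it against.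

Compound 4 `Cc1ccccc1-n1nc(C)c2c1NC(=O)[C@H](C)S[C@@H]2c1ccc(Oc2ccc(C(=O)O)cc2)cc1` is still to be measured in this assay. It differs from compound 3 in one place: 4-carboxyphenoxy in place of thiophen-3-yl on an aromatic carbon. Going by the values given here, no step between two measured compounds has been recorded; the expected size of the change from compound 3 to compound 4 therefore rests only on compound 3 at 1400 nM and on the fact that the other two compounds yielded no number at all. Compound 4 is estimated to improve on compound 3 by a modest margin, the step being a 2.3-fold lower number from compound 3 to compound 4 (0.37 log units; beyond the scatter), which is expected to lie beyond the scatter but not far beyond it. In this assay compound 4 is therefore expected to give about 600 nM, within a range from 150 nM to 2500 nM.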

Compound 4, half-maximal effective concentration: "not active" (no number reported)
Compound 4: no number reported; the estimate stays without a comparison.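

In this assay, for the compounds shown here, compound 4, like compound 1 and compound 2, returned no number, so no step from compound 3 to compound 4 can be read. Nothing shown here offers an explanation for this result. The compounds shown leave open how activity varies with the group on the aromatic ring, with compound 3 still the only quantified point.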